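A few compounds are considered here, and "the series" means these few. Any claim that something is new, unique, unknown or untested is made for them only; others in the source may bear on it.

Compound 1 `COc1ccccc1-c1csc2cnc(Nc3ccc(NC(=O)C4CCNCC4)cc3)nc12`: 450 nM
Compound 2 `COc1ccccc1-c1csc2cnc(Nc3ccc(NC(=O)[C@H]4CCCNC4)cc3)nc12`: 500 nM
Compound 3 `COc1ccccc1-c1csc2cnc(Nc3ccc(C(=O)NC4CCNCC4)c(C)c3)nc12`: 870 nM

These numbers come from a functional assay on A549 cells (Homo sapiens) for inhibition, read by MTT assay, with a stated time of 72 h; a lower number here means a stronger inhibitor, a higher number a weaker inhibitor. Compound 2 stands within the usual scatter of both compound 1 and compound 3. Compound 4 `COc1ccccc1-c1csc2cnc(Nc3ccc(NC(=O)CN)cc3)nc12` keeps the rest of compound 2 and changes one group: aminomethyl in place of piperidin-3-yl on a carbonyl carbon. In short, aminomethyl replaces piperidin-3-yl on a carbonyl carbon. Among the measured compounds shown here, the only measured step bearing on this is a 1.1-fold higher number from compound 1 to compound 2 (0.05 log units; within the scatter), with piperidin-3-yl in place of piperidin-4-yl. That step keeps the ring, so no measurement shows what losing it does in this assay. A modest rise in the number is expected, with wide uncertainty: the estimate is a 1.8-fold higher number from compound 2 to compound 4 (0.26 log units; within the scatter). Compound 4 is expected to give 900 nM, with an estimated range of 300 nM to 2700 nM.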

Compound 4, half-maximal inhibitory concentration: 1950 nM
Compound 4: the middle estimate sits 2.2-fold (0.34 log units) below what was measured; the range from low to high includes it.
By their numbers in this assay, from the lowest: compounds 1, 2 and 3 (each within the scatter of the next); then compound 4.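

In this assay, among the compounds shown here, the two piperidine groups gave numbers within the scatter of each other, so the earlier compounds did not show whether the ring could go. Replacing either group with aminomethyl on a carbonyl carbon gives a 3.9-fold higher number from compound 2 to compound 4 (0.59 log units; beyond the scatter) and a 4.3-fold higher number from compound 1 to compound 4 (0.64 log units; beyond the scatter) and both steps are modest but beyond the scatter, so this position does not accept every amine-bearing group alike. No measurement available here explains this loss. As far as these compounds go, what remains open is whether the ring itself matters or only the length of the group, which a 2-aminoethyl or 3-aminopropyl chain on the same carbonyl carbon could help to separate.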